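A few compounds are considered here, and "the series" means these few. Any claim that something is new, unique, unknown or untested is made for them only; others in the source may bear on it.

Measured so far:
Compound 1 `COc1c(O)cc(-c2coc3cc(O)cc(O)c3c2=O)cc1CC=C(C)C` gives 77000 nM in a functional assay on MDA-MB-231 cells (Homo sapiens) for cytotoxicity; a higher number here means that more compound is needed for the effect, a lower number that less compound is needed.
Compound 2 `C=C(C)/C=C/c1cc(-c2coc3cc(O)cc(O)c3c2=O)cc(O)c1OC` gives 13000 nM in this assay.

For the measured compounds named here, of these two numbers, compound 1 stands highest, and the single measured step is a 5.9-fold lower number from compound 1 to compound 2 (0.77 log units; beyond the scatter). Compound 3 `COc1ccc(-c2coc3cc(O)cc(O)c3c2=O)cc1CC=C(C)C` has not yet been measured. It differs from compound 1 in one place: hydrogen in place of hydroxy on an aromatic carbon. Going by the values given here, the only measured step alters the 3-methylbut-2-en-1-yl group and keeps the hydroxy in place, so it does not bear on the loss of a hydroxy; the data hold no step of that kind. With nothing comparable to lean on, the expectation for compound 3 is a number near that of compound 1, with no step beyond the scatter in this assay, expressed as a 1.2-fold higher number from compound 1 to compound 3 (0.07 log units; within the scatter). Compound 3 is therefore estimated at 90000 nM, with a range from 30000 nM to 250000 nM.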

Compound 3, half-maximal effective concentration: 27900 nM
Compound 3: the middle estimate sits 3.2-fold (0.51 log units) above what was measured; the whole stated range lies above it.
By their numbers in this assay, from the lowest: compound 2; then compound 3; then compound 1.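

In this assay the hydroxy on the aromatic carbon ortho to a methoxy group proves dispensable for the effect: hydrogen in its place gives a 2.8-fold lower number from compound 1 to compound 3 (0.44 log units; beyond the scatter) and so less compound is needed without it. For the compounds shown here, the earlier step touched only the 3-methylbut-2-en-1-yl group, so this is the first sign that the number also responds to a change at this second place on the aromatic ring, and here the loss of a group goes with a lower number. No measurement at hand accounts for this shift, so it stands as an observation only.

As far as these compounds go, whether a methoxy group, a fluorine atom or an amine at this place would lower the number as hydrogen does remains open. So does whether the same loss of hydroxy would give a similar step in compound 2, which carries the 3-methylbuta-1,3-dien-1-yl group.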